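The source may report more compounds than this note shows. Statements on the series, on what has been measured and on what is new or still open speak of the compounds shown alone.

Measured in a functional assay on the whole organism for antagonist activity, with Mus musculus as the target, in the maximal electroshock model; a higher number here means that more compound is needed for the effect, a lower number that less compound is needed:
- Compound 1 `COC(=O)NC1=NC(c2ccccc2)CN1C`: 107 mg/kg
- Compound 2 `COC(=O)NC1=NC(c2ccc(Cl)cc2)CN1C`: 66 mg/kg

Compound 2, at 66 mg/kg, stands level with compound 1 within the scatter, so the two values give no order. Compound 3 `COC(=O)NC1=NC(c2ccc(SC)cc2)CN1C` has not yet been measured. It carries methylsulfanyl in place of chloro on an aromatic carbon. Among the measured compounds shown here, no measured step makes this exchange directly. For the measured compounds named here, the one step that bears on it is a 1.6-fold lower number from compound 1 to compound 2 (0.21 log units; within the scatter), which puts chloro in place of hydrogen on an aromatic carbon and lies within the scatter. On that single small step, no change beyond the scatter is expected in this assay. The estimate amounts to an expected 1.1-fold higher number from compound 2 to compound 3 (0.03 log units; within the scatter). For compound 3 the estimated value is 70 mg/kg, with an expected range from 33 mg/kg to 150 mg/kg.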

Compound 3, dose for half-maximal effect: 100 mg/kg
The estimate for compound 3 lay 1.4-fold (0.15 log units) below the measured number; the range from low to high includes it.
By their numbers in this assay, from the lowest: compounds 2, 3 and 1 (each within the scatter of the next).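

In this assay the exchange at this position, on an aromatic carbon para to a large group, gives a 1.5-fold higher number from compound 2 to compound 3 (0.18 log units; within the scatter) and the placing of methylsulfanyl where hydrogen stood gives a 1.1-fold lower number from compound 1 to compound 3 (0.03 log units; within the scatter) so neither step leaves the scatter. Until now only chloro had been compared with hydrogen here; the result adds a second group, with two heavy atoms and one hydrogen-bond acceptor, and hydrogen, chloro and methylsulfanyl at this position still give no order among compounds 1, 2 and 3. No measurement at hand explains why these groups make so little difference.

The compounds shown leave open whether an amine, a carboxylic acid or a longer chain at this position would move the number beyond the scatter. They also leave open whether any change elsewhere on the shared core would do so.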